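A few compounds are considered here, and "the series" means these few. Any claim that something is new, unique, unknown or untested is made for them only; others in the source may bear on it.

Compound 1 `N#Cc1cnc(NCc2cnccc2C(F)(F)F)cc1NCC1CCOCC1`: in an assay on isolated protein for inhibition of protein kinase C delta type (Homo sapiens), read by TR-FRET, with a stated time of 2 h (on this read-out lower numbers stand for stronger inhibition and higher numbers for weaker inhibition), compound 1 gives 5000 nM.
Compound 2 `CNC(=O)[C@H]1CC[C@@H](Nc2cc(NCc3cnccc3C(F)(F)F)ncc2C#N)CC1`: in this assay compound 2 gives 1600 nM.
Compound 3 `CC1(C)C[C@H](Nc2cc(NCc3cnccc3C(F)(F)F)ncc2C#N)CC[C@H]1O`: in this assay compound 3 gives 2200 nM.

All three share one core and differ only in the group attached to a nitrogen on an aromatic ring. On the numbers shown, compound 3 stands second highest of three. Its nearest neighbour is compound 2, and that gap, a 1.4-fold higher number from compound 2 to compound 3 (0.14 log units; within the scatter), lies within the usual scatter, so no order between the two can be read. Compound 1 stands furthest away: a 2.3-fold lower number from compound 1 to compound 3 (0.36 log units; beyond the scatter) and a 3.1-fold lower number from compound 1 to compound 2 (0.49 log units; beyond the scatter) are both beyond the scatter, so compound 1 is the weaker of the set.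

Compound 4 `CC1(C)C[C@@H](Nc2cc(NCc3cnccc3C(F)(F)F)ncc2C#N)CC[C@H]1O` is the next step from compound 3. Its change is small on paper: the two compounds have the same atoms and bonds and differ only in configuration as drawn: 1 of 2 stereo elements differ; a stereocentre at a saturated ring carbon is drawn R in compound 3 and S in compound 4. For the measured compounds named here, every measured step swaps one whole group for another; none of them changes configuration alone, so no step bears directly on this one. Without such a guide, the expectation for compound 4 in this assay is a step of no clear size in either direction, most likely within the scatter, but with wide uncertainty. Compound 4 is therefore estimated at 2500 nM, within a range from 700 nM to 9000 nM, which means an expected step of a 1.1-fold higher number from compound 3 to compound 4 (0.06 log units; within the scatter).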

Compound 4, half-maximal inhibitory concentration: 2400 nM
Beside the measured number, compound 4's estimate is 1.0-fold (0.02 log units) above it, and the stated range covers the measured number.
By their numbers in this assay, from the lowest: compounds 2, 3 and 4 (each within the scatter of the next); then compound 1.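

For the compounds shown here, this is the first step that touches configuration alone. Turning a stereocentre at a saturated ring carbon from R to S gives no readable difference in this assay (a 1.1-fold higher number from compound 3 to compound 4 (0.04 log units; within the scatter)), so at this level of activity the assay does not separate the two drawings. The comparison is a clean one, because nothing else separates the pair: the fact that compounds 3 and 4 differ only in the configuration as drawn. The neighbours tell the same story, since compound 4 cannot be ordered against the methylcarbamoyl compound (a 1.5-fold higher number from compound 2 to compound 4 (0.18 log units; within the scatter)) but stands apart from the (oxan-4-yl)methyl compound (a 2.1-fold lower number from compound 1 to compound 4 (0.32 log units; beyond the scatter)), as compound 3 does.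

Going by these compounds alone, whether the other stereocentre, the one drawn alike in compounds 3 and 4, would matter in the same way stays open, as does whether the 3,3-dimethyl pair contributes anything to these numbers. From the compounds shown here alone, it is also open whether this lack of a difference would hold with another group on the cyclohexyl ring, such as an amine or a carboxylic acid in place of the hydroxy group.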